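The source may hold more compounds than are shown below. What is called first, only, known or untested is meant among the compounds shown, and "the series" means these compounds.

Compound 1 `Nc1cc(N)c2nc(-c3ccccc3)c(Sc3ccc(F)cc3)nc2c1`: < 100000 nM (a limit)
Compound 2 `COc1cc(CNc2nc3cc(N)cc(N)c3nc2-c2ccccc2)cc(OC)c1OC`: 11200 nM
Compound 3 `COc1ccc(CNc2nc3cc(N)cc(N)c3nc2-c2ccccc2)cc1OC`: 13500 nM

The three compounds share one core carrying two amino groups and a phenyl group, and differ in what hangs from the remaining position. In a functional assay on UO-31 cells (Homo sapiens) for inhibition, read by sulforhodamine B assay, with a stated time of 48 h (a higher number here means a weaker inhibitor of growth, a lower number a stronger inhibitor of growth), compound 1 gives < 100000 nM, which is a limit of the assay rather than a number, so where compound 1 stands among the others is open (the limit of < 100000 nM in this assay, at which 1 of the 3 values shown sits). Compound 2 gives 11200 nM in this assay, and compound 3 gives 13500 nM. Between them lies a 1.2-fold higher number from compound 2 to compound 3 (0.08 log units; within the scatter).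

Compound 4 `COc1ccc(Sc2nc3cc(N)cc(N)c3nc2-c2ccccc2)cc1` has not been measured. It differs from compound 1 by methoxy in place of fluoro on an aromatic carbon. Among the measured compounds shown here, no measured step touches the sulfanyl-linked ring of compound 1; the only measured step, a 1.2-fold higher number from compound 2 to compound 3 (0.08 log units; within the scatter), concerns a methoxy on the benzylamine side of compounds 2 and 3 and stays within the scatter, so it gives no sign that a methoxy moves the number far. Because compound 1 carries only a limit (the limit of < 100000 nM in this assay, at which 1 of the 3 values shown sits), the expected step that the limit leaves unreadable from compound 1 to compound 4 cannot be anchored to a known starting number. Compound 4 is therefore expected to give about 20000 nM in this assay, somewhere between 4000 nM and 100000 nM. That expectation leans on the range occupied by compounds 2 and 3, with a real chance that only a limit is reported again.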

Compound 4, concentration for 50% growth inhibition: 4170 nM
Beside the measured number, compound 4's estimate is 4.8-fold (0.68 log units) above it, within the range that was stated.
By their numbers in this assay, from the lowest: compound 4; then compounds 2 and 3 (each within the scatter of the next).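

The step from compound 1 to compound 4, methoxy in place of fluoro on an aromatic carbon, cannot be read, because compound 1 carries a limit rather than a number: the limit of < 100000 nM in this assay, at which 1 of the 4 values shown sits.

The compounds shown leave open how far the change from (4-fluorophenyl)sulfanyl to (4-methoxyphenyl)sulfanyl moves the number in this assay.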